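This account rests on a few compounds, and the source may have more. Where it says the series, first, only, none or still open, it means among the compounds named here.

Compound 1 `Cc1nc2c3ccccc3ccc2c2nc3c(ccc4ccccc43)c(-c3ccccc3S)c12` carries a 2-sulfanylphenyl group on its shared core. Within the data shown here, in a functional assay on HeLa cells (Homo sapiens) for cytotoxicity, read by MTT assay, with a stated time of 48 h (a higher number here means a weaker inhibitor, a lower number a stronger inhibitor), compound 1 gives 3190 nM, the lowest of the two numbers measured so far, although the nearest compound, compound 2 `Cc1nc2c3ccccc3ccc2c2nc3c(ccc4ccccc43)c(-c3cc([N+](=O)[O-])ccc3N)c12`, lies within the scatter of it: in this assay compound 2 gives 5770 nM. Among the measured compounds shown here, exchanging 2-amino-5-nitrophenyl for 2-sulfanylphenyl on that aromatic carbon gave a 1.8-fold higher number from compound 1 to compound 2 (0.26 log units; within the scatter), so the one measured exchange of the aryl group at this position left the number essentially unchanged.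

Compound 3 `Cc1nc2c3ccccc3ccc2c2nc3c(ccc4ccccc43)c(-c3cccc4ccccc34)c12` alters the same position: naphthalen-1-yl in place of 2-sulfanylphenyl on an aromatic carbon. For the measured compounds named here, the only measured step that bears on this change, the aryl swap between compound 1 and compound 2, stayed within the scatter, and nothing else among the measured compounds speaks to what a second aromatic ring at this carbon would do. The expectation for compound 3 therefore rests on that single comparison, and it is expected to show a 1.1-fold higher number from compound 1 to compound 3 (0.04 log units; within the scatter). Compound 3 is accordingly estimated at 3500 nM, within a range from 1200 nM to 10000 nM.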

Compound 3, half-maximal inhibitory concentration: 14900 nM
For compound 3 the middle estimate is 4.3-fold (0.63 log units) below the measured one, outside the stated range (above it).
By their numbers in this assay, from the lowest: compounds 1 and 2 (each within the scatter of the next); then compound 3.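

In this assay naphthalen-1-yl in place of 2-sulfanylphenyl gave a 4.7-fold higher number from compound 1 to compound 3 (0.67 log units; beyond the scatter) and in place of 2-amino-5-nitrophenyl gave a 2.6-fold higher number from compound 2 to compound 3 (0.41 log units; beyond the scatter) so this carbon, opposite the ring nitrogen, does respond to the aryl group it carries, which the one earlier exchange, within the scatter, had not shown. Both substituted phenyl groups, different as they are, stand on the lower side of naphthalen-1-yl, and the exchange from 2-sulfanylphenyl adds a second six-membered aromatic ring of carbon only while removing the sulfur with its hydrogen-bond donor and acceptor. No measurement at hand accounts for the higher number with naphthalen-1-yl.

As far as these compounds go, whether that higher number goes with the second aromatic ring or with the loss of the sulfanyl or amino group remains open, as each step changes both at once. A plain phenyl group or a 2-hydroxyphenyl group on this carbon would help separate the two readings, and naphthalen-2-yl would show whether the way the second ring is attached matters.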